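A few compounds are considered here, and "the series" means these few. Any claim that something is new, unique, unknown or untested is made for them only; others in the source may bear on it.

Compound 1, structure `O=c1ccc(CO)nn1Cc1ccccc1`, gives > 100000 nM in a functional assay on aorta (Rattus norvegicus); on this read-out higher numbers stand for weaker inhibition and lower numbers for stronger inhibition; this is a limit of the assay, not a number.
Compound 2, structure `O=c1ccc(CCO)nn1Cc1ccccc1`, gives > 100000 nM in this assay; again a limit.
Compound 3, structure `O=c1ccc(CO)n[nH]1`, gives > 100000 nM in this assay; again a limit.

From compound 1 to compound 2 the change is hydroxymethyl in place of hydroxy on a saturated chain carbon bound to an aromatic carbon. The step that the two limits leave unreadable from compound 1 to compound 2 cannot be read, because the limit of > 100000 nM in this assay, at which 3 of the 3 values shown sit, holds both compounds. The difference between the core of compound 1 and the core of compound 3 is not broken down here. Compound 4, structure `O=c1ccc(CCO)n[nH]1`, is not yet measured in this assay; it differs from compound 3 by hydroxymethyl in place of hydroxy on a saturated chain carbon bound to an aromatic carbon, the same change as from compound 1 to compound 2, at the same place. Since every measured compound in the series sits at a limit, the step from compound 3 to compound 4 is expected to be unreadable as well, written here as a step that the limit leaves unreadable from compound 3 to compound 4. Compound 4 is expected to give about 150000 nM in this assay, with a range from 50000 nM to 500000 nM, and most likely only a limit will be reported, because the limit of > 100000 nM in this assay, at which 3 of the 3 values shown sit, is where all shown values sit.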

Compound 4, half-maximal inhibitory concentration: > 100000 nM
Compound 4 gave a limit, no number; the forecaster's own chance of this, stated with the estimate: 85%; the middle value lies beyond the limit too.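

Compound 3 and compound 4 both stop at a limit, so the change between them yields no readable step, and the same holds for compound 1 and compound 2, because all four compounds rest at the same limit: the limit of > 100000 nM in this assay, at which 4 of the 4 values shown sit.

The compounds shown leave open whether hydroxymethyl, 2-hydroxyethyl or either core has any effect on inhibition in this assay.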